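The source may report more compounds than this note shows. Statements on the series, on what has been measured and on what is new or still open speak of the compounds shown alone.

Measured in a functional assay on HCT-116 cells (Homo sapiens) for inhibition, read by colorimetric assay, with a stated time of 3 days; on this read-out higher numbers stand for weaker inhibition and lower numbers for stronger inhibition:
- compound 1 `O=C(CCCCCCNC(=O)C(O)(O)C(F)(F)F)Nc1ccc(C(=O)c2ccccc2)cc1` gives > 40000 nM
- compound 2 `COc1cccc(NC(=O)CCCCCCNC(=O)C(O)(O)C(F)(F)F)c1` gives 6110 nM

The reading for compound 1 is a limit of the assay and not a number. Among the measured compounds shown here, compound 2 (6110 nM) therefore holds the only numerical value in this assay so far, and it cannot be ranked more finely than that.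

Next is compound 3 `O=C(CCCCCCNC(=O)C(O)(O)C(F)(F)F)Nc1ccc(F)cc1`, which carries 4-fluorophenyl in place of 3-methoxyphenyl on an amide-type nitrogen. For the measured compounds named here, no step between measured compounds is available to size this change, so the expectation rests on compound 2 (6110 nM) alone. A modest move toward weaker inhibition in this assay is expected (estimated step: a 1.3-fold higher number from compound 2 to compound 3 (0.12 log units; within the scatter)). For compound 3 the estimated value is 8000 nM (expected range 2500 nM to 25000 nM).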

Compound 3, half-maximal inhibitory concentration: 7570 nM
Compound 3: the middle estimate sits 1.1-fold (0.02 log units) above what was measured; the range from low to high includes it.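

In this assay, 4-fluorophenyl in place of 3-methoxyphenyl on the amide-type nitrogen gives a 1.2-fold higher number from compound 2 to compound 3 (0.09 log units; within the scatter), so these two aryl groups cannot be told apart on this read-out. Fluoro in place of benzoyl on an aromatic carbon gives an at least 5.2-fold lower number from compound 1 to compound 3 (0.72 log units; beyond the scatter), which is the first step in the series beyond the scatter and shows that the group carried on this aryl ring can matter. Compound 1 stands at a limit and not at a number, so this step has a minimum size only: the limit of > 40000 nM in this assay, at which 1 of the 3 values shown sits.

Still open, going by these compounds, is whether an unsubstituted phenyl, or an aryl ring carrying an amine or a carboxylic acid, would separate from compound 3. On these data alone, the effect of a longer chain on the shared core also remains unknown.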